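Methyl to Hydrogen on Selenium: Expected Toxicity of Compound 4

This account rests on a few compounds, and the source may have more. Where it says the series, first, only, none or still open, it means among the compounds named here.

In a functional assay on MCF7 cells (Homo sapiens) for cytotoxicity, read by MTT assay, with a stated time of 72 h (on this read-out higher numbers stand for lower toxicity in this test and lower numbers for higher toxicity in this test), compound 1 `COc1ccc(CNc2nc([Se]C)nc3ccccc23)cc1` reaches only the limit of the test, giving > 100000 nM. Compound 2 `C[Se]c1nc(N)c2ccccc2n1` likewise sits at the limit, with > 100000 nM. Among the measured compounds shown here, compound 3 `CSc1ccc(CNc2nc(SC)nc3ncccc23)cc1` is the one member with a true number, giving 9130 nM. So compound 1 stands at the limit of > 100000 nM in this assay, at which 2 of the 3 values shown sit. Compound 4 `COc1ccc(CNc2nc([SeH])nc3ccccc23)cc1` differs from compound 1 by hydrogen in place of methyl on a selenium. For the measured compounds named here, no measured pair shows such a change, so no size of step is known from the data. Because compound 1 sits at the limit of > 100000 nM in this assay, at which 2 of the 3 values shown sit, compound 4 is expected to stay near that limit, with an expected step of a number no higher from compound 1 to compound 4 (the limit leaves the size open). The estimate for compound 4 is 100000 nM, expected to fall between 30000 nM and 300000 nM.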

Compound 4, concentration lethal to 50% of the cells: > 100000 nM
Compound 4: a limit, no number; the forecaster's own chance of this, stated with the estimate: 60%; the middle value sits exactly at the limit.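

Compound 1 and compound 4 both sit at the limit of the test, so the step between them cannot be read. The compounds shown leave open whether hydrogen in place of methyl on a selenium changes toxicity at all.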